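Exchanging the Aryl Amine Group in a Thiourea Sulfonamide Series

A few compounds are considered here, and "the series" means these few. Any claim that something is new, unique, unknown or untested is made for them only; others in the source may bear on it.

Compound 1 `NS(=O)(=O)c1ccc(NC(=S)Nc2ccc3ncnc(Nc4ccc(Cl)c(C(F)(F)F)c4)c3c2)cc1` gives 4500 nM in a functional assay on A549 cells (Homo sapiens) for antiproliferative activity, read by MTT assay, with a stated time of 72 h; on this read-out higher numbers stand for weaker inhibition and lower numbers for stronger inhibition.
Compound 2 `NS(=O)(=O)c1ccc(NC(=S)Nc2ccc3ncnc(Nc4cccc(Cl)c4F)c3c2)cc1` gives > 40000 nM in this assay, which is a limit of the assay and not a number.
Compound 3 `NS(=O)(=O)c1ccc(NC(=S)Nc2ccc3ncnc(Nc4cccc(Cl)c4)c3c2)cc1` gives > 40000 nM in this assay, again a limit rather than a number.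

Compound 3 therefore sits at the edge of what this assay can report, a position it shares with one other compound (the limit of > 40000 nM in this assay, at which 2 of the 3 values shown sit). The step from compound 1 to compound 3 reads an at least 8.8-fold higher number from compound 1 to compound 3 (0.94 log units; beyond the scatter), while the step from compound 2 to compound 3 is a step that the two limits leave unreadable from compound 2 to compound 3.

Compound 4 `Cc1ccc(Nc2ncnc3ccc(NC(=S)Nc4ccc(S(N)(=O)=O)cc4)cc23)cc1` differs from compound 3 by 4-methylphenyl in place of 3-chlorophenyl on a nitrogen on an aromatic ring. Among the compounds with values here, the one readable step at this position, an at least 8.8-fold higher number from compound 1 to compound 3 (0.94 log units; beyond the scatter), shows that changing the aryl group here can shift the number strongly, but nothing measured shows a 4-methylphenyl group bringing it back down. The expected step is a number no higher from compound 3 to compound 4 (the limit leaves the size open), meaning little change beyond the scatter. Compound 4 is estimated at 40000 nM, with a range from 12000 nM to 100000 nM, and a real chance that only a limit is reported.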

Compound 4, half-maximal inhibitory concentration: 2840 nM
Compound 4: the middle estimate sits 14-fold (1.15 log units) above what was measured, and the stated range ends above it.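

This result shows that the aryl group on this nitrogen can restore a readable value without any chlorine: 4-methylphenyl in place of 3-chlorophenyl gives an at least 14-fold lower number from compound 3 to compound 4 (1.14 log units; beyond the scatter). The same holds against the 3-chloro-2-fluorophenyl group, with an at least 14-fold lower number from compound 2 to compound 4 (1.14 log units; beyond the scatter). The 4-methylphenyl group also matches the 4-chloro-3-(trifluoromethyl)phenyl group in this assay, with a 1.6-fold lower number from compound 1 to compound 4 (0.20 log units; within the scatter), so two very different aryl groups cannot be told apart here, while chlorine alone does not decide the outcome, as compound 1 carries it and remains readable.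

The change to compound 4 swaps both the substituent and its place on the ring, so a 3-methylphenyl or 4-chlorophenyl group would be needed to separate the two. The true size of the two large steps also stays open because compound 2 and compound 3 each report only a limit: the limit of > 40000 nM in this assay, at which 2 of the 4 values shown sit.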